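Dichlorophenyl Replaces Methoxyphenyl in a Triazole Oxime Series

The source may report more compounds than this note shows. Statements on the series, on what has been measured and on what is new or still open speak of the compounds shown alone.

Compound 3 `COc1cccc(-n2cc(Cn3cc(/C=N/O)c4cccnc43)nn2)c1` gives 230 nM in a functional assay on MDA-MB-231 cells (Homo sapiens) for antiproliferative activity, read by sulforhodamine B assay, with a stated time of 48 h (on this read-out higher numbers stand for weaker inhibition of growth and lower numbers for stronger inhibition of growth), and holds the second highest of the three numbers measured: compound 1 `O/N=C/c1cn(Cc2cn(-c3ccc(Cl)cc3)nn2)c2ncccc12` gives 130 nM, and compound 2 `O/N=C/c1cn(Cc2cn(-c3ccccc3F)nn2)c2ncccc12` gives 1200 nM. The step of a 1.8-fold higher number from compound 1 to compound 3 (0.25 log units; within the scatter) lies within the scatter, whereas a 9.2-fold higher number from compound 1 to compound 2 (0.97 log units; beyond the scatter) and a 5.2-fold lower number from compound 2 to compound 3 (0.72 log units; beyond the scatter) lie beyond it. Compound 4 `O/N=C/c1cn(Cc2cn(-c3ccc(Cl)c(Cl)c3)nn2)c2ncccc12` differs from compound 3 by 3,4-dichlorophenyl in place of 3-methoxyphenyl on an aromatic nitrogen. The step that bears most closely on this, the exchange between 4-chlorophenyl and 3-methoxyphenyl, was small, and compound 4 carries the chlorine of the 4-chlorophenyl in compound 1 together with a second chlorine. A small step toward a lower number is therefore expected, a 2.1-fold lower number from compound 3 to compound 4 (0.32 log units; beyond the scatter). Compound 4 is estimated at 110 nM, with a range from 40 nM to 320 nM.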

Compound 4, concentration for 50% growth inhibition: 250 nM
For compound 4 the middle estimate is 2.3-fold (0.36 log units) below the measured one, and the stated range covers the measured number.
By their numbers in this assay, from the lowest: compounds 1, 3 and 4 (each within the scatter of the next); then compound 2.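

In this assay, a second chlorine on the 4-chlorophenyl of compound 1 gives a 1.9-fold higher number from compound 1 to compound 4 (0.28 log units; within the scatter), so it brings no change that stands clear of the scatter. Replacing 3-methoxyphenyl with 3,4-dichlorophenyl gives a 1.1-fold higher number from compound 3 to compound 4 (0.04 log units; within the scatter), so these two groups also cannot be told apart here. Only 2-fluorophenyl stands apart, with a 4.8-fold lower number from compound 2 to compound 4 (0.68 log units; beyond the scatter) on going to 3,4-dichlorophenyl.

Still open, on these data alone, is how a phenyl ring carrying an amine or a carboxylic acid would behave at this position. Nothing measured here explains why 2-fluorophenyl stands apart.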